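From Methyl to Butyl: Estimating Compound 4

A few compounds are considered here, and "the series" means these few. Any claim that something is new, unique, unknown or untested is made for them only; others in the source may bear on it.

Compound 1 `COc1cc2nc(N3CCN(S(=O)(=O)c4ccc(Cl)cc4)CC3)nc(N)c2cc1OC` gives 23000 nM in a functional assay on PC-3 cells (Homo sapiens) for inhibition; on this read-out higher numbers stand for weaker inhibition and lower numbers for stronger inhibition.
Compound 2 `COc1cc2nc(N3CCN(S(=O)(=O)c4ccc(OC(F)(F)F)cc4)CC3)nc(N)c2cc1OC` gives 25000 nM in this assay.
Compound 3 `COc1cc2nc(N3CCN(S(=O)(=O)c4ccc(-c5ccc(C)cc5)cc4)CC3)nc(N)c2cc1OC` gives 3400 nM in this assay.

Compound 3 stands lowest of the three, set apart by a 6.8-fold lower number from compound 1 to compound 3 (0.83 log units; beyond the scatter) and a 7.4-fold lower number from compound 2 to compound 3 (0.87 log units; beyond the scatter), while a 1.1-fold higher number from compound 1 to compound 2 (0.04 log units; within the scatter) stays within the scatter. Compound 4 `CCCCc1ccc(-c2ccc(S(=O)(=O)N3CCN(c4nc(N)c5cc(OC)c(OC)cc5n4)CC3)cc2)cc1` differs from compound 3 by propyl in place of hydrogen on a saturated chain carbon bound to an aromatic carbon, so the 4-methylphenyl becomes a 4-butylphenyl. Going by the values given here, no measured step lengthens a chain; the two steps that bear on this position exchanged a small group for the whole 4-methylphenyl ring. Compound 4 is therefore expected to land near compound 3, with a 1.4-fold lower number from compound 3 to compound 4 (0.13 log units; within the scatter) as the estimated step. The estimate for compound 4 in this assay is 2500 nM, ranging from 800 nM to 8000 nM.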

Compound 4, half-maximal inhibitory concentration: 3400 nM
Compound 4: the middle estimate sits 1.4-fold (0.13 log units) below what was measured; measured number inside the range.
By their numbers in this assay, from the lowest: compounds 3 and 4 (each within the scatter of the next); then compounds 1 and 2 (each within the scatter of the next).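

In this assay, extending the methyl to butyl on the 4-methylphenyl leaves the read-out in place, with no change at the digits printed from compound 3 to compound 4 (within the scatter), so this chain can grow by a propyl without a readable change. The 4-butylphenyl also keeps the separation from the small groups, with a 7.4-fold lower number from compound 2 to compound 4 (0.87 log units; beyond the scatter) and a 6.8-fold lower number from compound 1 to compound 4 (0.83 log units; beyond the scatter), showing that this separation does not rest on the methyl alone. Nothing available explains why the added propyl leaves the number unchanged. On these data alone, whether a longer chain such as hexyl, or an amine or a carboxylic acid in place of the butyl, would hold this number stays open.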